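A few compounds are considered here, and "the series" means these few. Any claim that something is new, unique, unknown or untested is made for them only; others in the source may bear on it.

Compound 2 `CC1(C)CC(NC(=O)C(/C=C/[C@H](NC(=O)OC(C)(C)C)c2ccc(F)cc2)(Cc2ccc(F)cc2)Cc2ccc(F)cc2)CC(C)(C)N1` gives 340 nM in a functional assay on HT-1080 cells (Homo sapiens), read by luminescence, with a stated time of 24 h; a higher number here means that more compound is needed for the effect, a lower number that less compound is needed. Compound 1 `CC1(C)CC(NC(=O)C(/C=C/[C@@H](NC(=O)OC(C)(C)C)c2ccc(F)cc2)(Cc2ccc(F)cc2)Cc2ccc(F)cc2)CC(C)(C)N1` gives 280 nM in this assay, and compound 3 `CC(C)C[C@H](/C=C/C(C)(C)C(=O)NC1CC(C)(C)NC(C)(C)C1)NC(=O)OC(C)(C)C` gives 250 nM. All three numbers sit within the scatter of one another, so compound 2 is not set apart from either of the other two. Among the compounds with values here, the only step measured between compounds that differ in one place is a 1.2-fold higher number from compound 1 to compound 2 (0.08 log units; within the scatter); it rests on the fact that compounds 1 and 2 differ only in the configuration as drawn and bears on no exchange of groups.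

Compound 4 `CC(C)C[C@H](/C=C/C(Cc1ccc(F)cc1)(Cc1ccc(F)cc1)C(=O)NC1CC(C)(C)NC(C)(C)C1)NC(=O)OC(C)(C)C` differs from compound 2 by isobutyl in place of 4-fluorophenyl on a saturated chain carbon bound to an amide-type nitrogen and a double-bonded chain carbon. Within the data shown here, no measured step covers this exchange. Compound 3 already carries the isobutyl at that place, while its structure elsewhere departs from that of compound 2, and the two values sit within the scatter of each other. On this basis no step beyond the scatter is expected in this assay, that is a 1.2-fold lower number from compound 2 to compound 4 (0.07 log units; within the scatter). Compound 4 is estimated at 290 nM, with a range from 120 nM to 700 nM.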

Compound 4, half-maximal effective concentration: 180 nM
Estimate against measurement, compound 4: 1.6-fold (0.21 log units) above, and the stated range covers the measured number.
By their numbers in this assay, from the lowest: compounds 4, 3, 1 and 2 (each within the scatter of the next).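

In this assay, the exchange of 4-fluorophenyl for isobutyl on a saturated chain carbon bound to an amide-type nitrogen and a double-bonded chain carbon gives a 1.9-fold lower number from compound 2 to compound 4 (0.28 log units; within the scatter). Within the data shown here, this is the first measured step for a group exchange at this place, and it shows that an open-chain isobutyl, with fewer heavy atoms and no ring, can replace the aromatic group without a step beyond the scatter. Nothing shown gives a cause for this step.

On these data alone, with only these two groups compared at this place, the outcome for an amine, a carboxylic acid or a longer chain there remains open. Also open is how the opposite drawn configuration at this carbon would read with isobutyl, as compound 4 is the only compound shown that pairs isobutyl with the rest of this structure.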